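This account rests on a few compounds, and the source may have more. Where it says the series, first, only, none or still open, it means among the compounds named here.

Measured compounds so far:

- Compound 1, `CC(C)(C)[C@@H](O)C(=O)N1CSC[C@H]1C(=O)NCc1cc(Cl)ccc1-n1cnnn1`; in an ADME assay on liver for metabolic stability, with Liver microsome (Homo sapiens) as the target, read by LC-MS, using microsomes (a lower number here means slower removal, a higher number faster removal of the compound), compound 1 gives 120 mL.min-1.g-1.
- Compound 2, `CC1(C[C@@H](O)C(=O)N2C[C@H]3C[C@H]3[C@H]2C(=O)NCc2cc(Cl)ccc2-n2cnnn2)CC1`; in this assay compound 2 gives 12 mL.min-1.g-1.

Compound 2 stands at the lowest of the two numbers in hand. Its nearest neighbour on the numbers is compound 1, whose number lies well above it, beyond the usual scatter of this assay. Within the data shown here, the two compounds differ in more than one place, so no single counted step joins them; only their two values can be set side by side.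

Compound 3, `O=C(NCc1cc(Cl)ccc1-n1cnnn1)[C@@H]1[C@@H]2C[C@@H]2CN1C(=O)[C@H](O)Cc1ccccc1`, is not yet measured in this assay. It differs from compound 2 in one place: phenyl in place of 1-methylcyclopropyl on a saturated chain carbon, two bonds along the chain from a carbonyl carbon and an oxygen on a saturated carbon. Among the measured compounds shown here, no measured step with the same change exists, so the size of the step rests on judgement alone. A rise is expected, of a size close to the scatter rather than beyond it, and the step from compound 2 to compound 3 is estimated as a 1.7-fold higher number from compound 2 to compound 3 (0.22 log units; within the scatter). Compound 3 is therefore expected to give 20 mL.min-1.g-1, with a range from 7 mL.min-1.g-1 to 60 mL.min-1.g-1.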

Compound 3, intrinsic clearance in microsomes: 74 mL.min-1.g-1
Beside the measured number, compound 3's estimate is 3.7-fold (0.57 log units) below it, outside the stated range (above it).
By their numbers in this assay, from the lowest: compound 2; then compounds 3 and 1 (each within the scatter of the next).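

In this assay the exchange of 1-methylcyclopropyl for phenyl on a saturated chain carbon, two bonds along the chain from a carbonyl carbon and an oxygen on a saturated carbon, gives a 6.2-fold higher number from compound 2 to compound 3 (0.79 log units; beyond the scatter) and thus lies beyond the scatter. Among these compounds, this is the first single-place step, and it shows that the number in this assay is sensitive to the group held at this position, with the benzyl form on the side of faster removal than the (1-methylcyclopropyl)methyl form on this core. No measurement in hand bears on why the step has this size.

As far as these compounds go, a single pair on a single core carries this reading, so whether the same change gives a step of similar size on the core of compound 1 stays open. Also open, from the compounds shown here alone, is whether the rise goes with the aromatic ring or with the larger count of heavy atoms, a question that a cyclohexyl, a pyridyl, an amine or a carboxylic acid at this place could help to settle.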